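Chloro for methyl on the aniline ring of compound 1

This account rests on a few compounds, and the source may have more. Where it says the series, first, only, none or still open, it means among the compounds named here.

This account follows a single change made to compound 1, whose structure is `Cc1ccc(Nc2ccc(N3CC4CC(C3)N4)nn2)cc1`. Of the compounds shown here, three have been measured in an assay on cell membranes for displacement of a labelled ligand from Neuronal acetylcholine receptor; alpha4/beta2 (Rattus norvegicus); a higher number here means a weaker inhibitor, a lower number a stronger inhibitor. Compound 1 gives 44.3 nM, the highest number of the three. Compound 2, `Fc1ccc(Nc2cncc(N3CC4CC(C3)N4)c2)cc1`, gives 0.091 nM, and compound 3, `Clc1ccc(Nc2ccc(N3CC4CC(C3)N4)cn2)cc1Cl`, gives 2.3 nM; both of these stand beyond the scatter from compound 1, so compound 1 is the weakest inhibitor among the three measured compounds. Among the measured compounds shown here, compounds 2 and 3 carry different cores from compound 1, so no single-point step between measured compounds is available, and their values show only that halogen-bearing anilines on related cores reach lower numbers.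

Compound 4, `Clc1ccc(Nc2ccc(N3CC4CC(C3)N4)nn2)cc1`, differs from compound 1 in one place: chloro in place of methyl on an aromatic carbon. For the measured compounds named here, with no measured step of this kind on this core, the expectation rests on the general closeness of these two groups in size. A small step toward a lower number is expected, a 2.2-fold lower number from compound 1 to compound 4 (0.35 log units; beyond the scatter), not far beyond the scatter. Compound 4 is thus estimated at 20 nM, within a range from 5 nM to 80 nM in this assay.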

Compound 4, inhibition constant: 90.4 nM
For compound 4 the middle estimate is 4.5-fold (0.66 log units) below the measured one; measured number outside the range, above it.
By their numbers in this assay, from the lowest: compound 2; then compound 3; then compound 1; then compound 4.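

Among the compounds shown here, the pair gives the first one-place reading on this core: replacing methyl with chloro, that is 4-methylphenyl to 4-chlorophenyl, produces in this assay a 2.0-fold higher number from compound 1 to compound 4 (0.31 log units; beyond the scatter), a modest step that lies beyond the scatter. At this place on the aromatic ring, para to a large group, the change therefore moves the number up, something compounds 2 and 3 could not show, as each differs from compound 1 in more than one place. No measurement given here accounts for this step.

As far as these compounds go, it remains open whether a methoxy group, an amine or a fluoro group at the same place would give a higher or lower number than methyl or chloro. From the compounds shown here alone, it also remains open whether chloro in place of methyl would give a step of similar direction and size on the cores of compound 2 and compound 3.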